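Methylsulfonyl series: methyl for phenyl on the aryl ring

The source may report more compounds than this note shows. Statements on the series, on what has been measured and on what is new or still open speak of the compounds shown alone.

Measured so far in a functional assay on HT-29 cells (Homo sapiens) for cytotoxicity, read by MTT assay, with a stated time of 48 h, tested at 25 uM; a lower number here means a weaker effect, a higher number a stronger effect of the compound at the concentration tested:
- compound 1 `CS(=O)(=O)c1ccc(Cc2nnc3n2N=C(c2ccccc2)CS3)cc1`: 51%
- compound 2 `CS(=O)(=O)c1ccc(Cc2nnc3n2N=C(c2ccc(-c4ccccc4)cc2)CS3)cc1`: 60.2%
- compound 3 `CS(=O)(=O)c1ccc(Cc2nnc3n2N=C(c2cc(Cl)sc2Cl)CS3)cc1`: "not active" (no number reported), no number reported

Compound 2 holds the higher of the two numbers, with compound 1 nearest; the step of a number 9.2 percentage points higher from compound 1 to compound 2 (within the scatter) is within the scatter, so the two cannot be ordered. Compound 3 gives no number and contributes nothing to the size of steps.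

Compound 4 `Cc1ccc(C2=Nn3c(Cc4ccc(S(C)(=O)=O)cc4)nnc3SC2)cc1` is not yet measured. Its difference from compound 2 is methyl in place of phenyl on an aromatic carbon. For the measured compounds named here, the only step that bears on it is a number 9.2 percentage points higher from compound 1 to compound 2 (within the scatter), which introduced phenyl on the same aromatic carbon and moved the read-out by an amount within the scatter. Methyl in place of phenyl takes away most of what that step added while leaving a small substituent at the same place; nothing measured separates methyl from hydrogen or from phenyl here. The expected step in this assay is therefore small, in either direction, and not beyond the scatter.

For compound 4 the estimate is 55%, with a range from 40% to 68%. This expected value corresponds to a step of a number 5.2 percentage points lower from compound 2 to compound 4 (within the scatter).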

Compound 4, a percentage reported as activity, at one concentration (the size of the read-out at that concentration, not a potency): 1.26%
For compound 4 the middle estimate is 53.7 percentage points above the measured one, outside the stated range (below it).
By their numbers in this assay, from the lowest: compound 4; then compounds 1 and 2 (each within the scatter of the next).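

In this assay this aromatic carbon proves far more sensitive than the earlier pair suggested: hydrogen and phenyl could not be ordered, yet methyl gives a number 58.9 percentage points lower from compound 2 to compound 4 (beyond the scatter) and also a number 49.7 percentage points lower from compound 1 to compound 4 (beyond the scatter) in a second large step. Across these three compounds the read-out therefore does not follow the number of heavy atoms in the group, since methyl, with fewer heavy atoms than phenyl and more than hydrogen, falls outside the level shared by the two others and does not lie between them. Nothing among the data shown explains the drop.

Open, on these data alone, is whether the collapse belongs to methyl alone or extends to other small groups on the same aromatic carbon, which ethyl, methoxy, chlorine or an aminomethyl group in that place would help to separate. Also open, as far as these compounds go, is whether methyl in place of phenyl has a similar effect when the methylsulfonyl group on the other aryl ring is replaced, for example by a carboxylic acid or an amine.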